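Working notes: from compound 3 to compound 4

A few compounds are considered here, and "the series" means these few. Any claim that something is new, unique, unknown or untested is made for them only; others in the source may bear on it.

Values so far in a functional assay on HCC827 cells (Homo sapiens) for antiproliferative activity, read by MTT assay, with a stated time of 72 h (a higher number here means a weaker inhibitor, a lower number a stronger inhibitor), are as follows.
- compound 1 `COc1ccc(Nc2cc(NC(=O)c3ccccc3)ncn2)cc1` gives 5350 nM
- compound 2 `O=C(O)CCC(=O)Nc1cc(Nc2ccc(Cl)cc2)ncn1` gives 3130 nM
- compound 3 `COc1ccc(OC)c(Nc2cc(Nc3ccc(F)cc3)ncn2)c1` gives 1720 nM

Compound 3 (1720 nM) cannot be separated from compound 2 (3130 nM). The gap between them lies within the scatter. Compound 1 (5350 nM) is weaker than compound 3. That gap lies beyond the scatter.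

The next compound to be tested is compound 4 `COc1ccc(OC)c(Nc2cc(Nc3ccc(N4CCN(C)CC4)cc3)ncn2)c1`, which has 4-methylpiperazin-1-yl in place of fluoro on an aromatic carbon, para to a large group (4-methylpiperazin-1-yl in place of fluoro on an aromatic carbon). Among the measured compounds shown here, no two measured compounds differ in one place only, so the series gives no direct size for this change. The gap between compound 3 (1720 nM) and compound 1 (5350 nM) is modest despite their different structures, which makes a step of similar scale the working assumption. The direction remains a judgement that the data do not settle. A step toward a lower number in this assay, only just beyond the scatter, is expected (a 2.2-fold lower number from compound 3 to compound 4 (0.33 log units; beyond the scatter)). For compound 4 the estimated value is 800 nM with an expected range from 170 nM to 3500 nM in this assay.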

Compound 4, half-maximal inhibitory concentration: 24300 nM
Estimate against measurement, compound 4: 30-fold (1.48 log units) below; the measured number lies above the stated range.
By their numbers in this assay, from the lowest: compounds 3, 2 and 1 (each within the scatter of the next, the first and the last beyond it); then compound 4.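

In this assay, among the compounds shown here, the only step that changes one place gives a direct size for a change on this aromatic carbon, para to a large group, with a 14-fold higher number from compound 3 to compound 4 (1.15 log units; beyond the scatter) on going from fluoro to 4-methylpiperazin-1-yl. The position is therefore not indifferent to what it carries: with the rest of compound 3 held fixed, a group of 7 heavy atoms containing a six-membered non-aromatic ring with 2 hetero atoms is far less well tolerated in this antiproliferative read-out than a single fluorine. No measurement shown here bears on what lies behind this loss.

As far as these compounds go, it remains open whether the loss follows the ring itself, the methyl on its far nitrogen or simply the number of heavy atoms, and a morpholin-4-yl, a piperazin-1-yl without the methyl or a small dimethylamino group on the same carbon would separate these readings. From the compounds shown here alone, it is also open whether a step of this size would hold with a different group elsewhere in the molecule, since this change is seen on a single background.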